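Bromo for methoxy on a dithiolane-coumarin series

The compounds below may be only part of what the source reports. "The series", "measured", "known", "first", "only" and "open" are said of these compounds alone.

Three compounds sharing a dithiolane amide linked through a triazole to a coumarin core have been examined. Compound 1 `COc1ccc(-c2cc3ccc(OCCCn4cc(CNC(=O)CCCCC5CCSS5)nn4)cc3oc2=O)cc1` gives, in a functional assay on PC-12 cells (Rattus norvegicus) for cytotoxicity, read by MTT assay, with stated times of 3 h and 2 h, tested at 0.1 uM (on this read-out higher numbers stand for a stronger effect at the one concentration tested and lower numbers for a weaker effect), a value of 42%. Compound 2 `O=C(CCCCC1CCSS1)NCc1cn(CCCOc2ccc3cc(-c4ccc(Br)cc4)c(=O)oc3c2)nn1` differs from compound 1 in one place, (bromo in place of methoxy on an aromatic carbon), and in this assay compound 2 gives 39.5%. The step of a number 2.5 percentage points lower from compound 1 to compound 2 (within the scatter) is within the scatter of the measurement, so the two numbers cannot be told apart. Compound 3 `COc1ccc(-c2cc3ccc(OCCCCn4cc(CNC(=O)CCCCC5CCSS5)nn4)cc3oc2=O)cc1` differs from compound 1 by more than one place; how the two cores differ is not broken down here. In this assay compound 3 gives 32.1%, and its steps to compound 2 and compound 1 are both within the scatter as well.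

Compound 4 `O=C(CCCCC1CCSS1)NCc1cn(CCCCOc2ccc3cc(-c4ccc(Br)cc4)c(=O)oc3c2)nn1` has not yet been measured. It stands to compound 3 exactly as compound 2 stands to compound 1: the difference is bromo in place of methoxy on an aromatic carbon, the same change at the same kind of place, para to a large group on a six-membered aromatic ring of carbon only. Since this change left the read-out of compound 1 to compound 2 essentially unchanged, the step from compound 3 to compound 4 is expected to be small, a number 2.1 percentage points lower from compound 3 to compound 4 (within the scatter), because a number 2.5 percentage points lower from compound 1 to compound 2 (within the scatter) lay within the scatter. Compound 4 is therefore estimated to give 30% in this assay, within a range of 20% to 40%.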

Compound 4, a percentage reported as activity, at one concentration (the size of the read-out at that concentration, not a potency): 34.2%
The estimate for compound 4 lay 4.2 percentage points below the measured number; the measured number falls inside the stated range.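

In this assay, the change from 4-methoxyphenyl to 4-bromophenyl on the second core gives a number 2.1 percentage points higher from compound 3 to compound 4 (within the scatter), so compound 3 and compound 4 cannot be told apart, just as compound 1 and compound 2 could not. Set side by side, the two steps show that the exchange of methoxy for bromo reads the same on both cores, as far as this measurement can tell: the same change on two cores in this assay, a number 2.5 percentage points lower (within the scatter) from compound 1 to compound 2 and a number 2.1 percentage points higher (within the scatter) from compound 3 to compound 4, 4.6 percentage points apart, within the scatter of two such steps This is agreement between two steps that are each within the scatter, and it rests on two cores and a single concentration, so it shows that the change left no readable step here, but it does not show that the change is without effect under other conditions, says nothing about potency, and does not establish that the result would carry to any further core.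

The compounds shown carry only methoxy or bromo at this place on the aromatic ring, which leaves open how an amine, a carboxylic acid or a nitrile there would read. They also leave open whether a longer chain between the triazole and the shared core would give a step that could be told apart from the scatter.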